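A few compounds are considered here, and "the series" means these few. Any claim that something is new, unique, unknown or untested is made for them only; others in the source may bear on it.

Among the compounds with values here, in a functional assay on HepG2 cells (Homo sapiens) for inhibition, read by scintillation counting, with a stated time of 2 h (a higher number here means a weaker inhibitor, a lower number a stronger inhibitor), compound 2 `CCNC(=O)Nc1sc2ccccc2c1C(=O)N1CCN(C2CCN(C(=O)OC3CCCC3)CC2)CC1` gives 512 nM, the only number available so far, so it cannot yet be ranked against anything. Compound 1 `CCNC(=O)Nc1sc2ccccc2c1C(=O)N1CCN(C2CCN(C(=O)C(C)C)CC2)CC1` shares the same core, but its result reads "not determined" (no result reported). Compound 3 `CCNC(=O)Nc1sc2ccccc2c1C(=O)N1CCN(C2CCN(C(=O)OC(C)(C)C(F)(F)F)CC2)CC1` keeps that core and alters one group: 1-methyl-1-(trifluoromethyl)ethyl in place of cyclopentyl on an oxygen next to a carbonyl group. In words, 1-methyl-1-(trifluoromethyl)ethyl takes the place of cyclopentyl on an oxygen next to a carbonyl group, so a group with no ring replaces a five-membered one. Within the data shown here, no pair of measured compounds shows what a change at this place does, and the expectation rests on compound 2 at 512 nM alone. A small gain in strength is expected, though a result within the usual scatter would be no surprise, and the estimated change is a 1.6-fold lower number from compound 2 to compound 3 (0.20 log units; within the scatter). In this assay compound 3 is estimated at 320 nM, with an expected range from 90 nM to 1100 nM.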

Compound 3, half-maximal inhibitory concentration: 81 nM
Compound 3: middle estimate off by 4.0-fold (0.60 log units), on the high side; measured number below the stated range.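

In this assay, putting 1-methyl-1-(trifluoromethyl)ethyl in place of cyclopentyl on an oxygen next to a carbonyl group gives a 6.3-fold lower number from compound 2 to compound 3 (0.80 log units; beyond the scatter). Within the data shown here, this is the first measured step at this place, and it shows that the choice of group here changes the read-out by more than the usual scatter. It also shows that a five-membered ring is not required here for a number lower than that of compound 2, though no measurement accompanies the step to explain the gain.

This single step changes the ring and brings in fluorine together, so the effect of each remains unresolved, and a tert-butyl group on the same oxygen would help separate them. Compound 1 gives "not determined" (no result reported), so no comparison with it can be read.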